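Carbonyl substituent change from compound 2 to compound 4

The source may report more compounds than this note shows. Statements on the series, on what has been measured and on what is new or still open speak of the compounds shown alone.

Measured in a functional assay on A549 cells (Homo sapiens) for antiproliferative activity, read by sulforhodamine B assay, with a stated time of 48 h; a higher number here means a weaker inhibitor, a lower number a stronger inhibitor:
- Compound 1 `O=C1CSC(c2cccc(Br)c2)N1c1nccs1`: > 50000 nM
- Compound 2 `C=CCN(CC=C)C(=O)c1cccc(C2SCC(=O)N2c2ccccc2OC)c1`: > 50000 nM
- Compound 3 `COc1ccccc1N1C(=O)CSC1c1cccc(C(=O)N2CCCCC2)c1`: > 50000 nM

Each of these entries is a limit and not a number. Compound 2 stands at > 50000 nM, which is a limit, so there is no numerical starting point for the next step.

The next compound is compound 4 `COc1ccccc1N1C(=O)CSC1c1cccc(C(=O)NCCCc2ccccc2)c1`. Its difference from compound 2 is (3-phenylpropyl)amino in place of diallylamino on a carbonyl carbon. The entering group brings one six-membered aromatic ring of carbon only.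

For the measured compounds named here, the only measured step that bears on this change is a step that the two limits leave unreadable from compound 2 to compound 3, made on the same carbonyl carbon, and its size cannot be read. Going by the values given here, the series so far shows (the limit of > 50000 nM in this assay, at which 3 of the 3 values shown sit). Among the compounds with values here, no measured step therefore points to a change of any size or direction in this assay, and none beyond the scatter is expected. The expected step is a number no higher from compound 2 to compound 4 (the limit leaves the size open), an estimate that rests on no measured number.

Another limit is the most likely outcome for compound 4. For compound 4 the estimated value is 50000 nM, with an expected range of 15000 nM to 100000 nM.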

Compound 4, half-maximal inhibitory concentration: 31600 nM
Beside the measured number, compound 4's estimate is 1.6-fold (0.20 log units) above it; the range from low to high includes it.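

In this assay compound 4 gives 31600 nM, so a substituent on this carbonyl carbon can give a measured number in this series. The other compounds shown do not leave the limit: the limit of > 50000 nM in this assay, at which 3 of the 4 values shown sit.

The change reads as an at least 1.5-fold lower number from compound 2 to compound 4 (0.19 log units; that floor lies within the scatter) and as an at least 1.5-fold lower number from compound 3 to compound 4 (0.19 log units; that floor lies within the scatter); both are floors set by a limit and not measured sizes, and the step between the two limits of compound 2 and compound 3 cannot be read. Relative to diallylamino, (3-phenylpropyl)amino brings one six-membered aromatic ring of carbon only together with the amide hydrogen, and compound 4 does not separate these two features.

As far as these compounds go, it remains open whether the true gap to the compounds at the limit lies beyond the scatter, and whether the aromatic ring, the chain or the amide hydrogen accounts for the number. Benzylamino, with a shorter chain to the ring, and propylamino, with the same chain and no ring, on the same carbonyl carbon would bear directly on that question.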